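The compounds below may be only part of what the source reports. "The series", "measured", "known", "first", "only" and "open" are said of these compounds alone.

Among the compounds with values here, compound 3 `O=C(O)C[C@H](O)C[C@H](O)CCn1c(-c2ccc(F)cc2)nc(C(=O)NCc2ccc(F)cc2)c1C1CC1` carries the highest number of the three measured so far in a functional assay on cells (Hepatocyte, Rattus norvegicus) for inhibition, read by scintillation counting, with a stated time of 4 h (on this read-out higher numbers stand for weaker inhibition and lower numbers for stronger inhibition), where compound 3 gives 0.7 nM; compound 2 `O=C(O)C[C@H](O)C[C@H](O)CCn1c(-c2ccc(F)cc2)nc(C(=O)NCc2ccc(F)c(F)c2)c1C1CC1` gives 0.5 nM, and compound 1 `COc1cccc(CNC(=O)c2nc(-c3ccc(F)cc3)n(CC[C@@H](O)C[C@@H](O)CC(=O)O)c2C2CC2)c1` gives 0.2 nM. The steps of a 1.4-fold higher number from compound 2 to compound 3 (0.15 log units; within the scatter) and a 3.5-fold higher number from compound 1 to compound 3 (0.54 log units; beyond the scatter) place compound 3 close to compound 2 and clearly apart from compound 1. Compound 4 `COc1ccccc1CNC(=O)c1nc(-c2ccc(F)cc2)n(CC[C@@H](O)C[C@@H](O)CC(=O)O)c1C1CC1` differs from compound 3 by 2-methoxyphenyl in place of 4-fluorophenyl on a saturated chain carbon bound to an amide-type nitrogen. On these data alone, the step that bears on this is a 3.5-fold higher number from compound 1 to compound 3 (0.54 log units; beyond the scatter), run in the opposite direction, with a 2.5-fold higher number from compound 1 to compound 2 (0.40 log units; beyond the scatter) as the other exchange of this aryl group; both were modest, and 2-methoxyphenyl itself is untested here, so the size is uncertain. A modest move to a lower number is therefore expected, a 2.3-fold lower number from compound 3 to compound 4 (0.37 log units; beyond the scatter), because compound 1 with 3-methoxyphenyl gives 0.2 nM. Compound 4 is expected at 0.3 nM, within 0.1 nM to 1 nM.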

Compound 4, half-maximal inhibitory concentration: 0.1 nM
Compound 4: middle estimate off by 3.0-fold (0.48 log units), on the high side; the range from low to high includes it.
By their numbers in this assay, from the lowest: compounds 4 and 1 (each within the scatter of the next); then compounds 2 and 3 (each within the scatter of the next).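

At this place in this assay, 2-methoxyphenyl in place of 4-fluorophenyl gives a 7.0-fold lower number from compound 3 to compound 4 (0.85 log units; beyond the scatter) and in place of 3,4-difluorophenyl gives a 5.0-fold lower number from compound 2 to compound 4 (0.70 log units; beyond the scatter) and so stands clearly apart from both fluorinated aryl groups. In place of 3-methoxyphenyl it gives a 2.0-fold lower number from compound 1 to compound 4 (0.30 log units; within the scatter) and so leaves the two methoxyphenyl compounds unseparated, with compound 1 and compound 4 both apart from compound 2 and compound 3. Nothing available gives a reason for this split. On these data alone, whether 4-methoxyphenyl, 2-ethoxyphenyl or 2-hydroxyphenyl would sit with the methoxyphenyl pair stays open. Also open, as far as these compounds go, is whether unsubstituted phenyl would sit with that pair or with the fluorinated compounds.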